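The compounds below may be only part of what the source reports. "The series", "measured", "known", "first", "only" and "open" are said of these compounds alone.

Measured compounds:
compound 1 `NC(=O)c1cc[n+](CCC[n+]2cc(Cl)c(/C=N/O)c(Cl)c2)cc1` — 1.73 10^-6 cm/s
compound 2 `NC(=O)c1cc[n+](CCCC[n+]2ccc(/C=N/O)c(Cl)c2)cc1` — 1 10^-6 cm/s
compound 3 `NC(=O)c1cc[n+](C/C=C/C[n+]2cc(Cl)c(/C=N/O)c(Cl)c2)cc1` — 2.21 10^-6 cm/s

Series of bis-pyridinium oximes in an ADME assay for permeability, using PAMPA, with a stated time of 6 h, tested at 100 uM; on this read-out lower numbers stand for lower permeability and higher numbers for higher permeability. Within the three numbers in hand, compound 1 stands second highest; its nearest neighbour is compound 3, whose number is within the scatter of it, and the furthest is compound 2, which also lies within the scatter. All three measured values therefore sit in one band, and no order among them can be read from this assay.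

Compound 4 `NC(=O)c1cc[n+](CCC[n+]2ccc(/C=N/O)c(Cl)c2)cc1` is not yet measured. It differs from compound 1 in one place: hydrogen in place of chloro on an aromatic carbon. Compound 2 shares this mono-chloro pattern on the oxime-bearing ring, though with a different linker, and in this assay compound 2 gives 1 10^-6 cm/s. For the measured compounds named here, no step between measured compounds separates the chloro change from the linker change, so the expectation rests on the band occupied by compounds 1 to 3. The step from compound 1 to compound 4 is expected to be small, if anything a slight decrease, and not beyond the scatter: a 1.3-fold lower number from compound 1 to compound 4 (0.12 log units; within the scatter). Compound 4 is accordingly estimated at 1.3 10^-6 cm/s, with a range from 0.7 10^-6 cm/s to 2.5 10^-6 cm/s.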

Compound 4, apparent permeability: 1.4 10^-6 cm/s
For compound 4 the middle estimate is 1.1-fold (0.03 log units) below the measured one; low and high end bracket the measured number.
By their numbers in this assay, from the lowest: compounds 2, 4, 1 and 3 (each within the scatter of the next, the first and the last beyond it).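

In this assay, for the compounds shown here, the earlier compounds could not separate the chloro pattern from the linker, whereas here a single swap is read with the linker held constant: hydrogen in place of chloro on an aromatic carbon, ortho to a group of 3 heavy atoms and two atoms from the ring nitrogen, gives a 1.2-fold lower number from compound 1 to compound 4 (0.09 log units; within the scatter) and places both compounds in one band. At this position, then, the chloro group of compound 1 is not needed to stay within the scatter of its value, although this single pair cannot show whether that holds for the same swap on another linker. Nothing available gives a measured reason for the size of this step.

Going by these compounds, whether an amine or a carboxylic acid at this same position would give a number beyond the scatter of compound 1 remains open. Also open, on these data alone, are what replacing the chloro group that remains in compound 4 would do and whether a longer chain between the two rings would leave this swap equally small.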